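Cytotoxicity notes: 4-iodophenyl replacing 3-methylphenyl

A few compounds are considered here, and "the series" means these few. Any claim that something is new, unique, unknown or untested is made for them only; others in the source may bear on it.

Compound 3 `Cc1cccc(CNCc2cc(=O)c3c(O)c(O)ccc3o2)c1` is the point of departure. In an ADME assay on Huh-7 cells (Homo sapiens) for cytotoxicity (on this read-out higher numbers stand for lower toxicity in this test and lower numbers for higher toxicity in this test), compound 3 gives > 100000 nM, which is a limit of the assay and not a number. Compound 1 `O=c1cc(CNCc2cccc(F)c2)oc2ccc(O)c(O)c12` gives > 100000 nM in this assay, again only a limit. Compound 2 `O=c1cc(CNCc2cccc(Cl)c2)oc2ccc(O)c(O)c12` gives > 100000 nM in this assay, also a limit. All three therefore sit at the limit of > 100000 nM in this assay, at which 3 of the 3 values shown sit, and nothing separates them on the numbers shown. The step that the two limits leave unreadable from compound 1 to compound 2 is accordingly of unknown size. The two steps that reach compound 3 directly, a step that the two limits leave unreadable from compound 1 to compound 3 and a step that the two limits leave unreadable from compound 2 to compound 3, are likewise unreadable, so no direction and no size can be taken from them.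

Compound 4 `O=c1cc(CNCc2ccc(I)cc2)oc2ccc(O)c(O)c12` differs from compound 3 by 4-iodophenyl in place of 3-methylphenyl on a saturated chain carbon bound to an amine nitrogen. With every measured step hidden by the same limit, no step beyond the scatter is expected in this assay. Compound 4 is expected to give about 150000 nM in this assay, within 50000 nM to 500000 nM. The step that the limit leaves unreadable from compound 3 to compound 4 that this estimate implies is expected to be none beyond the scatter, most likely reported again as a limit.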

Compound 4, half-maximal cytotoxic concentration: 41700 nM
For compound 4 the middle estimate is 3.6-fold (0.56 log units) above the measured one; measured number outside the range, below it.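

In this assay, going by these compounds alone, the place on a saturated chain carbon bound to an amine nitrogen proves able to move the read-out, which the earlier compounds could not show: 4-iodophenyl gives an at least 2.3-fold lower number from compound 3 to compound 4 (0.37 log units; beyond the scatter), and the comparisons with the two halogen analogues give an at least 2.3-fold lower number from compound 2 to compound 4 (0.37 log units; beyond the scatter) and an at least 2.3-fold lower number from compound 1 to compound 4 (0.37 log units; beyond the scatter). Each of these steps starts from a limit, so each gives only a minimum size, and the true steps may be larger. Compound 4 is the only compound shown with a number, while the other three share one limit: the limit of > 100000 nM in this assay, at which 3 of the 4 values shown sit.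

From the compounds shown here alone, the steps among compound 1, compound 2 and compound 3 still cannot be read. 4-Iodophenyl changes both the substituent and its numbered ring position, so it remains open whether 3-iodophenyl or 4-chlorophenyl would also leave the limit.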